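The compounds below may be only part of what the source reports. "The series", "measured", "known", "first", "only" and "open" are said of these compounds alone.

Compound 1 `COc1ccc(Nc2nc3c(Cl)ncnc3s2)cc1` is one of three related compounds tested in an assay on CHO cells for displacement of a labelled ligand from adenosine receptor A3 (Homo sapiens), read by scintillation counting, with a stated time of 3 h (on this read-out higher numbers stand for weaker inhibition and lower numbers for stronger inhibition), and in this assay compound 1 gives 5880 nM. Compound 2 `Clc1ccc(Nc2nc3c(N4CCCC4)ncnc3s2)cc1` gives 4260 nM, a number within the scatter of that of compound 1, while compound 3 `Cc1ccc(Nc2nc3c(N4CCCC4)ncnc3s2)cc1` gives 563 nM, the lowest of the three. Going by the values given here, the only measured single-point step, a 7.6-fold lower number from compound 2 to compound 3 (0.88 log units; beyond the scatter), concerns the substituent on the six-membered aromatic ring of carbon only. Compound 4 `Clc1ncnc2sc(Nc3ccccc3)nc12` differs from compound 1 by hydrogen in place of methoxy on an aromatic carbon. Among the compounds with values here, no measured step removes a group from that ring, so nothing observed bears directly on this change, and no step beyond the scatter is expected. Compound 4 is estimated at 5000 nM, with a range from 1500 nM to 16000 nM. This is expected to amount to a 1.2-fold lower number from compound 1 to compound 4 (0.07 log units; within the scatter).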

Compound 4, inhibition constant: 3670 nM
Compound 4: the middle estimate sits 1.4-fold (0.13 log units) above what was measured; the range from low to high includes it.
By their numbers in this assay, from the lowest: compound 3; then compounds 4, 2 and 1 (each within the scatter of the next).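

Replacing methoxy with hydrogen on the six-membered aromatic ring of carbon only gives a 1.6-fold lower number from compound 1 to compound 4 (0.20 log units; within the scatter), so the two compounds cannot be told apart in this measurement. Going by these compounds alone, this is the first measured change that removes a group from this ring, and it shows that compound 1 does not depend on its methoxy group to keep its measured level of inhibition. Nothing available explains why this change has so small an effect.

Going by these compounds, how an amine, a carboxylic acid or a longer chain would behave at this position remains open. So does whether hydrogen here would have an equally small effect on the core of compound 3.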